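The compounds below may be only part of what the source reports. "The series", "measured", "known", "first", "only" and "open" are said of these compounds alone.

Measured compounds:
compound 1 `COc1c(OCCCCN2CCN(C)CC2)cc(O)c2c(=O)cc(-c3ccc(Br)cc3)oc12` gives 4330 nM
compound 2 `CCN(CC)CCCOc1c(OCc2ccccc2)cc(O)c2c(=O)cc(-c3ccccc3)oc12` gives 4900 nM

Both numbers come from a functional assay on B16 cells (Mus musculus) for cytotoxicity, read by MTT assay, with a stated time of 72 h; on this read-out higher numbers stand for weaker inhibition and lower numbers for stronger inhibition. On these two numbers compound 2 stands highest, but its nearest value, that of compound 1, lies within the usual scatter of this assay, so no order between the two can be read from them. Within the data shown here, compound 1 and compound 2 differ from each other in several places at once, and no pair of measured compounds differs in a single place, so the series offers no calibrated single step to lean on.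

Compound 3 `CN(C)CCCCOc1c(OCc2ccccc2)cc(O)c2c(=O)cc(-c3ccccc3)oc12` remains to be measured in this assay. It differs from compound 2 by (dimethylamino)methyl in place of diethylamino on a saturated chain carbon, three bonds along the chain from an oxygen on an aromatic ring. Nothing measured bears directly on this change. Among the measured compounds shown here, the only guide is that the two measured compounds, despite differing in several places, land within the scatter of each other, so the step from compound 2 to compound 3 is expected to be small, in no fixed direction, and not beyond the scatter. Compound 3 is estimated at 4900 nM in this assay, with a range from 2000 nM to 12000 nM, which means an expected step of no change at the digits printed from compound 2 to compound 3 (within the scatter).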

Compound 3, half-maximal inhibitory concentration: 3220 nM
Compound 3: the middle estimate sits 1.5-fold (0.18 log units) above what was measured, within the range that was stated.
By their numbers in this assay, from the lowest: compounds 3, 1 and 2 (each within the scatter of the next).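

In this assay, the exchange of diethylamino for (dimethylamino)methyl on a saturated chain carbon, three bonds along the chain from an oxygen on an aromatic ring, gives a 1.5-fold lower number from compound 2 to compound 3 (0.18 log units; within the scatter). Among these compounds, this is the first single-place step, which compounds 1 and 2 alone could not supply, and it shows that 3-(diethylamino)propyl and 4-(dimethylamino)butyl cannot be told apart on this read-out. No measurement accompanies the step that could account for it.

On these data alone, the step combines two edits, a longer chain and methyl in place of ethyl on the nitrogen, so their separate contributions remain open; 3-(dimethylamino)propyl and 4-(diethylamino)butyl at the same place would part them. Also open, as far as these compounds go, is whether a different chain end, such as a morpholine or a carboxylic acid, would give a step beyond the scatter at this position.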